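The compounds below may be only part of what the source reports. "The series", "measured", "known", "first", "only" and "open" are said of these compounds alone.

Measured compounds:
Compound 1 `CCOc1ccc(-n2nncc2CN2C(=O)C3(C(C#N)=C(N)Oc4c3c3nc5ccccc5nc3c3ccccc43)c3ccccc32)cc1`; in an ADME assay on L02 cells (Homo sapiens) for antiproliferative activity, read by MTT assay, with a stated time of 48 h (a lower number here means a stronger inhibitor, a higher number a weaker inhibitor), compound 1 gives > 50000 nM, which is a limit of the assay and not a number.
Compound 2 `COc1ccccc1-n1nncc1CN1C(=O)C2(C(C#N)=C(N)Oc3c(N)cc4nc5ccccc5nc4c32)c2ccccc21`; in this assay compound 2 gives > 50000 nM, again a limit of the assay and not a number.

For the measured compounds named here, compound 2 therefore stands at the edge of what this assay can report, and it shares that position with the only other measured compound (the limit of > 50000 nM in this assay, at which 2 of the 2 values shown sit). Going by the values given here, no step between measured compounds is available, so nothing shows yet how far any single change moves the read-out.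

Compound 3 `N#CC1=C(N)Oc2c(N)cc3nc4ccccc4nc3c2C12C(=O)N(Cc1cnnn1-c1ccc([N+](=O)[O-])cc1[N+](=O)[O-])c1ccccc12` differs from compound 2 in one place (2,4-dinitrophenyl in place of 2-methoxyphenyl on an aromatic nitrogen). Since both measured compounds sit at the limit, no direction can be read from them; the expectation is a step from compound 2 to compound 3 of no more than the scatter, most likely again a limit, a number no higher from compound 2 to compound 3 (the limit leaves the size open). For compound 3 in this assay the estimate is 50000 nM, ranging from 20000 nM to 100000 nM.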

Compound 3, half-maximal inhibitory concentration: 22800 nM
Beside the measured number, compound 3's estimate is 2.2-fold (0.34 log units) above it, and the stated range covers the measured number.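

In this assay, replacing 2-methoxyphenyl with 2,4-dinitrophenyl on the aromatic nitrogen gives an at least 2.1-fold lower number from compound 2 to compound 3 (0.34 log units; beyond the scatter). This is the first sign that the read-out responds to a change at this place, and compound 3 is the only compound shown that gives a number rather than a limit of the assay. The other two compounds remain at that limit, so the full size of the step stays unknown: the limit of > 50000 nM in this assay, at which 2 of the 3 values shown sit.

The compounds shown leave open whether both nitro groups are needed for this step, or whether a single one would give the same result. They also leave open how an aminophenyl group, a carboxylic acid on the phenyl ring or a plain alkyl chain at this nitrogen would read in this assay.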